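Swapping a Dichlorophenyl for a Methylphenyl on a Shared Core

The compounds below may be only part of what the source reports. "The series", "measured", "known", "first", "only" and "open" are said of these compounds alone.

Measured compounds:
- compound 1, `COc1ccccc1/C=c1/[nH]c(=O)/c(=C\c2ccccc2OC)n(C)c1=O`: "not active" (no number reported)
- compound 2, `C=CCn1c(=O)/c(=C\c2ccc(Cl)c(Cl)c2)[nH]c(=O)/c1=C\c1ccccc1OC`: "not active" (no number reported)
- compound 3, `COc1ccccc1/C=c1\c(=O)[nH]/c(=C/c2cccc(Cl)c2Cl)c(=O)n1C`: 300 nM

All three were tested in a functional assay on BGC-823 cells (Homo sapiens) for cytotoxicity, read by CCK-8 assay, with a stated time of 72 h; a higher number here means a weaker inhibitor, a lower number a stronger inhibitor. Compound 2 stands without a single number here: in this assay compound 2 is recorded as "not active" (no number reported). It shares that fate with one further entry, since compound 1 is likewise recorded as "not active" (no number reported). Among the compounds with values here, only compound 3 gives a number, 300 nM in this assay, and compound 3 differs from compound 2 in more than one place, so no single step between them can be read out.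

The unmeasured compound 4, `C=CCn1c(=O)/c(=C\c2ccc(C)cc2)[nH]c(=O)/c1=C\c1ccccc1OC`, follows from compound 2 by one change: 4-methylphenyl in place of 3,4-dichlorophenyl on a double-bonded chain carbon bound to an aromatic carbon. Within the data shown here, no measured pair shows this change in isolation, so there is nothing to anchor the size or direction of the step in this assay. With compound 2 reported as "not active" (no number reported), the expectation is that compound 4 stays at the weak end, most likely again without a number, and any number it does give is expected to be large. The estimate for compound 4 in this assay is 20000 nM, within a range from 3000 nM to 100000 nM.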

Compound 4, half-maximal inhibitory concentration: "not active" (no number reported)
Nothing numeric was reported for compound 4, so the estimate cannot be set against anything.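

Compound 2 and compound 4 both lack a number in this assay, so no step can be read from the change of 3,4-dichlorophenyl to 4-methylphenyl. Nothing shown here offers an explanation for this result. The compounds shown leave open whether this change would alter the potency of a compound that does give a number.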